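The source may hold more compounds than are shown below. What is called first, only, known or untested is meant among the compounds shown, and "the series" means these compounds.

Compound 1 `COc1ccc(/C=N/NC(=S)NC(C)(C)[C@H]2CC=C(C)CC2)cc1` in a functional assay on 786-0 cells (Homo sapiens) for inhibition, read by sulforhodamine B assay, with a stated time of 48 h (a lower number here means a stronger inhibitor of growth, a higher number a weaker inhibitor of growth), gives 29600 nM. Compound 2 `CC1=CC[C@H](C(C)(C)NC(=S)N/N=C/c2ccccc2Cl)CC1` in this assay gives > 100000 nM, which is a limit of the assay and not a number.

Compound 2 therefore stands at the edge of what this assay can report: the measurement shows only that its growth inhibition is weak, with no exact figure, as noted in the limit of > 100000 nM in this assay, at which 1 of the 2 values shown sits. Compound 3 `CC1=CC[C@H](C(C)(C)NC(=S)N/N=C/c2cccc(Cl)c2)CC1` differs from compound 2 in one place: 3-chlorophenyl in place of 2-chlorophenyl on a carbon with a double bond to nitrogen. Going by the values given here, the only measured step, an at least 3.3-fold higher number from compound 1 to compound 2 (0.52 log units; beyond the scatter), exchanged a different group on the same carbon and does not compare two chlorophenyl groups, so it bears on this step only by showing how far the shared core of compound 2 already sits from a measurable value. Among the compounds with values here, no step within the data predicts a shift beyond the scatter for compound 3 in this assay. The expected outcome for compound 3 is 90000 nM (range 25000 nM to 300000 nM), an estimated step of an at least 1.1-fold lower number from compound 2 to compound 3 (0.04 log units; that floor lies within the scatter).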

Compound 3, concentration for total growth inhibition: 26900 nM
For compound 3 the middle estimate is 3.3-fold (0.52 log units) above the measured one; low and high end bracket the measured number.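

Moving the chlorine on the same ring is enough to change the result, although the atoms stay the same: in this assay, 3-chlorophenyl in place of 2-chlorophenyl gives a clear gain in growth inhibition (an at least 3.7-fold lower number from compound 2 to compound 3 (0.57 log units; beyond the scatter)). With 3-chlorophenyl in place of 4-methoxyphenyl, the two compounds cannot be told apart (a 1.1-fold lower number from compound 1 to compound 3 (0.04 log units; within the scatter)), so on this carbon a chlorine-bearing ring can match the methoxy-bearing one, depending on where the chlorine sits. The value of compound 2 is a limit of the assay and not a number, so the first step gives only a floor for the change: the limit of > 100000 nM in this assay, at which 1 of the 3 values shown sits.

Still open, from the compounds shown here alone, is how a 4-chlorophenyl group, or a phenyl ring carrying an amine or a carboxylic acid instead of the chlorine, would compare with compound 3. The compounds shown also cannot tell whether this difference between the two chlorophenyl groups would hold on another core.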